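Methoxy for methyl in the carboxypiperidine series

The source may report more compounds than this note shows. Statements on the series, on what has been measured and on what is new or still open speak of the compounds shown alone.

Measured in a physicochemical assay for solubility; on this read-out higher numbers stand for higher solubility and lower numbers for lower solubility:
- compound 1 `O=C(Nc1nc(-c2cccc(C(F)(F)F)c2F)cs1)c1cnc(N2CCC(C(=O)O)CC2)c(Br)c1`: < 10 ug/mL (a limit)
- compound 2 `O=C(Nc1nc(-c2cccc(C(F)(F)F)c2F)cs1)c1cnc(N2CCC(C(=O)O)CC2)c(C(F)(F)F)c1`: < 10 ug/mL (a limit)
- compound 3 `Cc1cc(C(=O)Nc2nc(-c3cccc(C(F)(F)F)c3F)cs2)cnc1N1CCC(C(=O)O)CC1`: < 10 ug/mL (a limit)

Compound 3 gives only a limit, < 10 ug/mL, and no number. The same holds across the series: the limit of < 10 ug/mL in this assay, at which 3 of the 3 values shown sit.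

Compound 4 `COc1cc(C(=O)Nc2nc(-c3cccc(C(F)(F)F)c3F)cs2)cnc1N1CCC(C(=O)O)CC1` carries methoxy in place of methyl on an aromatic carbon, ortho to a 4-carboxypiperidin-1-yl group (methoxy in place of methyl on an aromatic carbon).

The nearest measured changes at this place are a step that the two limits leave unreadable from compound 1 to compound 3 and a step that the two limits leave unreadable from compound 2 to compound 3, with a step that the two limits leave unreadable from compound 1 to compound 2 alongside them. None gives a size to carry over, so no step beyond the scatter is expected in this assay, and no direction is expected either. The expected step is a step that the limit leaves unreadable from compound 3 to compound 4. Compound 4 is estimated at 6 ug/mL, with an expected range of 3 ug/mL to 14 ug/mL.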

Compound 4, solubility: < 10 ug/mL
Compound 4: a limit, no number; the forecaster's own chance of this, stated with the estimate: 80%; the middle value does not contradict the limit.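

No step can be read in this assay among compound 1, compound 2, compound 3 and compound 4, since all four give only a limit: the limit of < 10 ug/mL in this assay, at which 4 of the 4 values shown sit.

The compounds shown leave open whether bromo, trifluoromethyl, methyl and methoxy at this place differ at all on this read-out.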